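The compounds below may be only part of what the source reports. "The series", "measured", "known", "first", "only" and "open" are said of these compounds alone.

Three compounds sharing one core were tested in a functional assay on MCF7 cells (Homo sapiens) for cytotoxicity, read by MTT assay, with a stated time of 72 h; a lower number here means a stronger inhibitor, a higher number a weaker inhibitor. Compound 1 `COc1ccc(-c2ccnc(C(=O)Nc3ccc(Oc4ccnc5[nH]ccc45)cc3)n2)cc1` carries a methoxy group, and in this assay compound 1 gives 12400 nM, a weak result. Compound 2 `O=C(Nc1ccc(Oc2ccnc3[nH]ccc23)cc1)c1nccc(-c2ccc(Cl)cc2)n1` carries a chloro group instead; in this assay compound 2 is reported as "not active" (no number reported), with no number recorded. Compound 3 `O=C(Nc1ccc(Oc2ccnc3[nH]ccc23)cc1)c1nccc(-c2ccc(F)cc2)n1` carries a fluoro group, and in this assay compound 3 is likewise reported as "not active" (no number reported). For the measured compounds named here, compound 2 thus stands among the two compounds of the set for which no single number exists, while the only number in the set, that of compound 1, already speaks of weak inhibition.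

Compound 4 `O=C(Nc1ccc(Oc2ccnc3[nH]ccc23)c(F)c1)c1nccc(-c2ccc(Cl)cc2)n1` is the next compound. It differs from compound 2 by fluoro in place of hydrogen on an aromatic carbon. Going by the values given here, no measured pair of this kind is available in the set, so the size of this step in this assay cannot be read from the data; the expectation is a step of no size beyond the usual scatter, with weak inhibition remaining. Compound 4 is therefore expected to give about 25000 nM in this assay, within a range from 8000 nM to 80000 nM, and with a real chance that again only an inactive call and no number is reported.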

Compound 4, half-maximal inhibitory concentration: 9660 nM
Beside the measured number, compound 4's estimate is 2.6-fold (0.41 log units) above it, and the stated range covers the measured number.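

For the compounds shown here, compound 2 has only an inactive call in this assay and compound 4 gives 9660 nM there, which leaves no step to read between the two. Going by these compounds, the size of the effect of the added fluoro group stays open, as does any difference among the methoxy, chloro and fluoro compounds 1, 2 and 3. No further evidence bears on this result.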